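The compounds below may be only part of what the source reports. "The series", "measured", "known", "first", "only" and "open" are said of these compounds alone.

In a functional assay on KYSE-450 cells (Homo sapiens) for inhibition, read by CCK-8 assay, with a stated time of 48 h (a higher number here means a weaker inhibitor, a lower number a stronger inhibitor), two compounds of this series have been measured so far. Compound 1 `CCN1CCN(C(=S)SCC(=O)N(Cc2ccc(OC)cc2)c2cc(OC)c(OC)c(OC)c2)CC1` gives 3070 nM, the higher of the two numbers, and compound 2 `COc1ccc(CN(C(=O)CSC(=S)N2CCN(C(C)=O)CC2)c2cc(OC)c(OC)c(OC)c2)cc1` gives 370 nM. Compound 3 `COc1ccc(CN(C(=O)CSC(=S)N2CCN(Cc3ccc(C(C)(C)C)cc3)CC2)c2cc(OC)c(OC)c(OC)c2)cc1` keeps the core of compound 1 and differs at one place: 4-(tert-butyl)phenyl in place of methyl on a saturated chain carbon bound to an amine nitrogen in a ring. Read one bond further out, this is ethyl to 4-(tert-butyl)benzyl, on the same amine nitrogen in a ring that carries the acetyl of compound 2. Within the data shown here, only one measured step bears on the change. Acetyl in place of ethyl on that nitrogen gave an 8.3-fold lower number from compound 1 to compound 2 (0.92 log units; beyond the scatter), a modest step beyond the scatter. Among the measured compounds shown here, it shows that the number can move with a change at this nitrogen, but the entering group there is a different one, and no measured compound carries a benzyl group at this place. On these data alone, the direction for compound 3 therefore stays open, with only a slight lean toward a lower number. The estimated step is a 1.7-fold lower number from compound 1 to compound 3 (0.23 log units; within the scatter), and no change beyond the scatter is firmly expected in this assay. Compound 3 is expected at 1800 nM, with an estimated range from 350 nM to 7000 nM.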

Compound 3, half-maximal inhibitory concentration: 2140 nM
Beside the measured number, compound 3's estimate is 1.2-fold (0.08 log units) below it; low and high end bracket the measured number.
By their numbers in this assay, from the lowest: compound 2; then compounds 3 and 1 (each within the scatter of the next).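

Placing 4-(tert-butyl)benzyl on the amine nitrogen in a ring, where compound 1 carries ethyl, gives a 1.4-fold lower number from compound 1 to compound 3 (0.16 log units; within the scatter) in this assay, so this much larger entering group, with its six-membered aromatic ring, leaves the number within the scatter of the ethyl compound. Measured against the acetyl of compound 2, the same group gives a 5.8-fold higher number from compound 2 to compound 3 (0.76 log units; beyond the scatter), which shows that the lower number of compound 2 is not shared by every change away from ethyl at this nitrogen: among the three compounds, only the acetyl one stands apart from the other two. Nothing at hand explains why acetyl stands apart or why ethyl and 4-(tert-butyl)benzyl sit together.

The three groups shown cannot tell whether the lower number belongs to acetyl alone or extends to other groups joined through a carbonyl, such as propionyl or benzoyl. On these data alone, it also remains open how a plain benzyl group, without the tert-butyl, or a methanesulfonyl group on the same nitrogen would read in this assay, with the rest of the core of compound 1 unchanged.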